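The source may hold more compounds than are shown below. What is called first, only, known or untested is meant among the compounds shown, and "the series" means these compounds.

Measured so far: compound 1 `CC(NC(=O)c1ccc(C(C)(C)C)cc1)c1ccc(C(=O)O)cc1` with 76 nM; compound 2 `CC(C)(C)c1ccc(C(=O)NCc2ccc(S(N)(=O)=O)cc2)cc1` with 1400 nM; compound 3 `O=C(O)c1ccc(CNC(=O)c2ccc3ccccc3c2)cc1` with 1360 nM.

In an assay on HeLa cells with Bile acid receptor (Homo sapiens) as the target, read by a luciferase reporter, with a stated time of 24 h (a lower number here means that less compound is needed, a higher number that more compound is needed for the effect), compound 2 gives 1400 nM, the highest of the three numbers. Compound 3, with 1360 nM, sits within the scatter of it, whereas compound 1, with 76 nM, lies well beyond it. Compound 4 `CC(C)(C)c1ccc(C(=O)NCc2ccc(CCC(=O)O)cc2)cc1` has not yet been measured. It differs from compound 2 in one place: 2-carboxyethyl in place of sulfamoyl on an aromatic carbon. For the measured compounds named here, no measured pair shows this exact change, so the size of the step is uncertain. Compound 1 carries a carboxylic acid and gives 76 nM, which points toward a lower number for compound 4; compound 3 also carries one and gives 1360 nM, so the expected gain is modest. Compound 4 is expected near 500 nM, in a range from 150 nM to 1600 nM. The estimated step is a 2.8-fold lower number from compound 2 to compound 4 (0.45 log units; beyond the scatter).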

Compound 4, half-maximal effective concentration: 350 nM
Compound 4: middle estimate off by 1.4-fold (0.15 log units), on the high side; low and high end bracket the measured number.
By their numbers in this assay, from the lowest: compound 1; then compound 4; then compounds 3 and 2 (each within the scatter of the next).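

In this assay, 2-carboxyethyl in place of sulfamoyl on an aromatic carbon para to a large group gives a 4.0-fold lower number from compound 2 to compound 4 (0.60 log units; beyond the scatter). This is the first pair shown that differs in one place, and it shows that the number responds to the group at this position. Nothing measured here accounts for the step. The compounds shown leave open how a shorter or longer chain ending in a carboxylic acid would compare with 2-carboxyethyl. They also leave open whether a primary amide or a hydroxyl at the chain end would give a similar number.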